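Removing a methyl from the fused bicyclic amine of compound 2

The source may hold more compounds than are shown below. What is called first, only, known or untested is meant among the compounds shown, and "the series" means these compounds.

Compound 1 `O=C(Nc1ccc2cccnc2c1)c1ccc(-c2cccc(F)c2)nc1` gives 8.6 in an in vitro functional assay on 1321-N1 cells for antagonist activity at transient receptor potential cation channel subfamily V member 1 (Homo sapiens), read by FLIPR and calcium flux; on this read-out higher numbers stand for higher potency (the scale is a negative logarithm) and lower numbers for lower potency. Compound 2 `Cc1nc2ccc(NC(=O)c3ccc(-c4ccc(F)cc4)nc3C)cc2[nH]1` gives 6 in this assay, which is the lower of the two numbers shown, sitting well beyond the scatter from compound 1. Compound 3 `Cc1nc(-c2ccc(F)cc2)ccc1C(=O)Nc1ccc2sc(N(C)C)nc2c1` reaches only a limit of the assay, < 5.8, in this assay; this is the limit of < 5.8 in this assay, at which 1 of the 3 values shown sits, and it is not a number. Compound 4 `Cc1nc(-c2ccc(F)cc2)ccc1C(=O)Nc1ccc2nc[nH]c2c1` has not yet been measured. It differs from compound 2 in one place: hydrogen in place of methyl on an aromatic carbon. Going by the values given here, no pair of measured compounds that differs only in this way is available, so the size of the step is not known from the data. As the change is the loss of a single carbon on the fused ring system, the step from compound 2 to compound 4, no change at the digits printed from compound 2 to compound 4 (within the scatter), is expected to be small and not beyond the usual scatter. Compound 4 is therefore estimated at 6 in this assay, with a range from 5.5 to 6.5.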

Compound 4, negative logarithm of the antagonist equilibrium constant: 7.2
Compound 4: the middle estimate sits 1.20 log units below what was measured; the whole stated range lies below it.
By their numbers in this assay, from the lowest: compound 2; then compound 4; then compound 1. At a limit, below all of these: compound 3.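

In this assay, the aromatic carbon of the five-membered aromatic ring, between two ring nitrogen atoms, proves sensitive to the loss of a single carbon: hydrogen in place of methyl here brings a number 1.20 log units higher from compound 2 to compound 4 (beyond the scatter) for this pair. This is the first pair shown that differs in only one place, so the earlier compounds, which differ in more than one place, could not isolate the effect of this position. Nothing among the data shown gives a cause for this step.

Going by these compounds, how an ethyl group or an amine on this same carbon would compare with hydrogen and methyl remains open. On these data alone, it is also open whether the same change would bring a step of similar size with a different group on the other side of the amide.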